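Replacing the Amide of Compound 1 with an Ester

The source may report more compounds than this note shows. Statements on the series, on what has been measured and on what is new or still open speak of the compounds shown alone.

Of the compounds shown here, two have been measured in a functional assay on MT4 cells (Homo sapiens) for antiproliferative activity, read by MTT assay, with a stated time of 96 h; on this read-out lower numbers stand for an effect already at smaller amounts and higher numbers for an effect only at larger amounts of compound. Compound 1 `N#C/C(=C\c1c(-c2ccccc2)[nH]c2ccccc12)C(N)=O` gives 6000 nM in this assay, the higher of the two numbers shown. Compound 2 `COc1ccc(-c2[nH]c3ccc(OC)cc3c2/C=C(\C#N)S(=O)(=O)c2ccccc2)cc1`, which shares the general shape but carries other groups on its core, gives 200 nM in this assay, a lower number that lies beyond the usual scatter; the two differ in several places at once, so no single change accounts for the gap.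

Compound 3 `COCCOC(=O)/C(C#N)=C/c1c(-c2ccccc2)[nH]c2ccccc12` has not yet been measured. It differs from compound 1 in one place: 2-methoxyethoxy in place of amino on a carbonyl carbon. For the measured compounds named here, no measured pair shows this change, so its effect is unknown here. The expectation is a modest step from compound 1 to compound 3 of a 2.0-fold lower number from compound 1 to compound 3 (0.30 log units; within the scatter), toward a somewhat lower number, although a result within the scatter would not surprise. Compound 3 is accordingly estimated at 3000 nM, with a likely range from 800 nM to 15000 nM in this assay.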

Compound 3, half-maximal effective concentration: 1200 nM
For compound 3 the middle estimate is 2.5-fold (0.40 log units) above the measured one; the measured number falls inside the stated range.
By their numbers in this assay, from the lowest: compound 2; then compound 3; then compound 1.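

For the compounds shown here, this is the first step that changes only one place, and in this assay it gives a 5.0-fold lower number from compound 1 to compound 3 (0.70 log units; beyond the scatter), a difference beyond the usual scatter. The carbonyl carbon therefore does not depend on its amino group for the effect on these cells: 2-methoxyethoxy, with five heavy atoms and no hydrogen-bond donor, can take its place and the number still falls. What lies behind this drop cannot be said, as no measurement here speaks to its cause.

As far as these compounds go, the amino group leaves and the 2-methoxyethoxy chain enters in the same step, so it remains open whether the gain comes from the ester link itself or from the chain it carries; a plain methoxy on the same carbonyl carbon would separate the two, and a longer chain with further ether oxygens would show whether the trend continues. A carboxylic acid or a substituted amide at this place would also test how much of the carbonyl's surroundings can vary while the number stays low.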